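This account rests on a few compounds, and the source may have more. Where it says the series, first, only, none or still open, it means among the compounds named here.

Compound 2 `O=C(/C=C\c1ccc(O)cc1)N1N=C(c2ccncc2)OC1c1c[nH]c2ccccc12` is known in an ADME assay on PANC-1 cells (Homo sapiens) for cytotoxicity, read by MTT assay, with a stated time of 48 h (on this read-out lower numbers stand for stronger inhibition of growth and higher numbers for weaker inhibition of growth), only as a limit: in that assay compound 2 gives > 30 ug/mL. Compound 1 `O=C(/C=C\c1cccc(O)c1)N1N=C(c2ccncc2)OC1c1c[nH]c2ccccc12` likewise reaches only a limit, > 30 ug/mL. The step that the two limits leave unreadable from compound 1 to compound 2 therefore cannot be read, and the limit of > 30 ug/mL in this assay, at which 2 of the 2 values shown sit, is all that the two values show. Compound 3 `O=C(/C=C\c1cccc([N+](=O)[O-])c1)N1N=C(c2ccncc2)OC1c1c[nH]c2ccccc12` differs from compound 2 by 3-nitrophenyl in place of 4-hydroxyphenyl on a double-bonded chain carbon bound to a double-bonded chain carbon. Within the data shown here, for compound 3 no measured step bears on this change, and the step that the limit leaves unreadable from compound 2 to compound 3 is estimated without a measured anchor. Compound 3 is expected at 40 ug/mL, between 12 ug/mL and 120 ug/mL.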

Compound 3, concentration for 50% growth inhibition: > 30 ug/mL
Compound 3: only a limit was reported; the forecaster's own chance of this, stated with the estimate: 70%; the middle value lies beyond the limit too.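

No step can be read from compound 1 to compound 3 or from compound 2 to compound 3, since all three compounds stop at a limit in this assay: the limit of > 30 ug/mL in this assay, at which 3 of the 3 values shown sit. The compounds shown leave open how strongly each inhibits growth, and whether 3-nitrophenyl in place of 4-hydroxyphenyl changes this at all.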